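A few compounds are considered here, and "the series" means these few. Any claim that something is new, unique, unknown or untested is made for them only; others in the source may bear on it.

Working notes on the series. Compound 1 `CC1(c2ccccc2)NC(=O)N(Cc2ccc(C(=O)NO)cc2)C1=O` gives 74.9 nM in an assay on isolated protein for inhibition of protein deacetylase HDAC6 (Homo sapiens), read by fluorescence, with stated times of 10 min and 2 h; a higher number here means a weaker inhibitor, a lower number a stronger inhibitor. Compound 2 `CC(C)(C)c1ccc(CC2(c3ccccc3)NC(=O)N(Cc3ccc(C(=O)NO)cc3)C2=O)cc1` gives 115 nM, and compound 3 `O=C(NO)c1ccc(CN2C(=O)NC(CCc3ccccc3)(c3ccccc3)C2=O)cc1` gives 24.7 nM. Compound 3 stands lowest of the three numbers: the step of a 3.0-fold lower number from compound 1 to compound 3 (0.48 log units; beyond the scatter) is beyond the scatter, as is a 4.7-fold lower number from compound 2 to compound 3 (0.67 log units; beyond the scatter), whereas a 1.5-fold higher number from compound 1 to compound 2 (0.19 log units; within the scatter) stays within it. Compound 4 `O=C(NO)c1ccc(CN2C(=O)NC(Cc3cccc4ccccc34)(c3ccccc3)C2=O)cc1` is not yet measured. The change is naphthalen-1-yl in place of benzyl on a saturated chain carbon bound to a saturated ring carbon. The two steps that bear on it both concern groups at this same chain carbon: a benzyl there lowered the number moderately, while a directly attached aryl (compound 2) gave no gain over hydrogen and sat above compound 3. Compound 4 carries a directly attached aryl again, so the expectation for compound 4 in this assay is a small step toward a higher number than compound 3, of the order of the step to compound 2 or less, possibly within the scatter. The estimated step of a 2.0-fold higher number from compound 3 to compound 4 (0.31 log units; beyond the scatter) is thus expected to be small. Compound 4 is expected at 50 nM, within 20 nM to 130 nM.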

Compound 4, half-maximal inhibitory concentration: 91.9 nM
Estimate against measurement, compound 4: 1.8-fold (0.26 log units) below; measured number inside the range.
By their numbers in this assay, from the lowest: compound 3; then compounds 1, 4 and 2 (each within the scatter of the next).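

In this assay, naphthalen-1-yl in place of benzyl on the saturated chain carbon bound to a saturated ring carbon gives a 3.7-fold higher number from compound 3 to compound 4 (0.57 log units; beyond the scatter), so the lower number of compound 3 does not carry over to this group with two six-membered aromatic rings. The other steps, a 1.2-fold higher number from compound 1 to compound 4 (0.09 log units; within the scatter) and a 1.3-fold lower number from compound 2 to compound 4 (0.10 log units; within the scatter), are both within the scatter, leaving compound 3 as the only one of the four that stands apart at this place. Nothing on hand accounts for this difference.

From the compounds shown here alone, whether the lower number of compound 3 persists with a longer chain at this place remains open. Also open, going by these compounds, is how an amine or a carboxylic acid on the terminal phenyl ring of that chain would read.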